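Swapping 3-methylphenyl for 4-(methylcarbamoyl)phenyl on the shared core

The compounds below may be only part of what the source reports. "The series", "measured", "known", "first", "only" and "open" are said of these compounds alone.

- compound 1 `CN(C)c1ccc2nnc(Cc3ccc4ncccc4c3)n2n1` gives 35 mL.min-1.g-1
- compound 2 `COc1ccc(-c2ccc3nnc([C@@H](C)c4ccc5ncccc5c4)n3n2)cc1C` gives 304 mL.min-1.g-1
- compound 3 `Cc1cccc(-c2ccc3nnc([C@@H](C)c4ccc5ncccc5c4)n3n2)c1` gives 81.8 mL.min-1.g-1

In an ADME assay on microsomes from liver (Homo sapiens) for metabolic stability, read by LC-MS, with a stated time of 30 min, tested at 1 uM (on this read-out higher numbers stand for fast clearance and lower numbers for slow clearance), compound 3 (81.8 mL.min-1.g-1) holds the middle place: compound 1 (35 mL.min-1.g-1) lies lower and compound 2 (304 mL.min-1.g-1) lies higher, with both gaps beyond the usual scatter.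

Next comes compound 4 `CNC(=O)c1ccc(-c2ccc3nnc([C@@H](C)c4ccc5ncccc5c4)n3n2)cc1` which keeps the shared core and changes one group (4-(methylcarbamoyl)phenyl in place of 3-methylphenyl on an aromatic carbon). In words, 4-(methylcarbamoyl)phenyl stands in place of 3-methylphenyl on an aromatic carbon.

Among the measured compounds shown here, only one measured step alters the carbon-only aromatic ring at this place (a 3.7-fold lower number from compound 2 to compound 3 (0.57 log units; beyond the scatter)). There, hydrogen replaces methoxy, and the step is modest. It shows that an edit to this group can move the number beyond the scatter, but it is only an indirect guide. For the measured compounds named here, no measured compound carries the methylcarbamoyl group.

The estimated step (a 2.2-fold lower number from compound 3 to compound 4 (0.33 log units; beyond the scatter)) is therefore expected to be of similar modest size and toward a lower number. That direction is a judgement, not a trend seen in the data. Compound 4 is estimated at 38 mL.min-1.g-1 within an expected range (15 mL.min-1.g-1 to 95 mL.min-1.g-1).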

Compound 4, intrinsic clearance in microsomes: 12.2 mL.min-1.g-1
Compound 4: middle estimate off by 3.1-fold (0.49 log units), on the high side; the measured number lies below the stated range.
By their numbers in this assay, from the lowest: compound 4; then compound 1; then compound 3; then compound 2.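

In this assay the change to 4-(methylcarbamoyl)phenyl gives a 6.7-fold lower number from compound 3 to compound 4 (0.83 log units; beyond the scatter) and, set against the methoxy-bearing ring, a 25-fold lower number from compound 2 to compound 4 (1.40 log units; beyond the scatter) on the same shared core. The earlier compounds shown here showed only what removing a methoxy group from this ring can do, whereas these steps show that putting a carbonyl-containing amide group on the ring goes with a lower clearance number against both of the other ring groups, so compound 4 now has the lowest number of the three compounds that carry a ring at this place. The data offer no measurement that explains why the number falls.

The methyl group and the ring position of the substituent both change along with the amide, so the compounds shown do not separate what each part contributes. From the compounds shown here alone, it remains open whether a carboxylic acid, a nitrile or an amide without the methyl group, placed on the same ring, would give a similarly low number in this assay or a quite different one.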